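Removing the chlorine from the benzyl ether of compound 3

This account rests on a few compounds, and the source may have more. Where it says the series, first, only, none or still open, it means among the compounds named here.

Three ureas on a shared core have been measured in a functional assay on GBM1 cells (Homo sapiens) for antiproliferative activity, read by WST assay, with a stated time of 72 h; a lower number here means a stronger inhibitor, a higher number a weaker inhibitor. Compound 1 `O=C(Nc1cccc(F)c1)Nc1cc2ncncc2cc1OCc1cccc(Cl)c1` gives 3700 nM. Compound 2 `O=C(Nc1ccccc1F)Nc1cc2ncncc2cc1OCc1cccc(Cl)c1` gives 4200 nM. Compound 3 `O=C(Nc1ccc(C(F)(F)F)cc1)Nc1cc2ncncc2cc1OCc1cccc(Cl)c1` gives 3400 nM. The steps among them, a 1.1-fold higher number from compound 1 to compound 2 (0.06 log units; within the scatter), a 1.1-fold lower number from compound 1 to compound 3 (0.04 log units; within the scatter) and a 1.2-fold lower number from compound 2 to compound 3 (0.09 log units; within the scatter), all lie within the scatter, so the three aryl groups on the urea nitrogen leave this assay essentially unchanged; compound 3 carries the lowest of the three numbers but cannot be called the most potent on this evidence.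

Compound 4 `O=C(Nc1ccc(C(F)(F)F)cc1)Nc1cc2ncncc2cc1OCc1ccccc1` keeps the aryl urea of compound 3 and differs only at the benzyl ether: hydrogen in place of chloro on an aromatic carbon. Among the compounds with values here, no measured step touches this part of the molecule; all three steps so far vary the aryl on the urea nitrogen and stay within the scatter. Within the data shown here, there is thus no direct precedent for the chloro-to-hydrogen change, and the only guide is that the peripheral changes made so far have produced no movement beyond the scatter. The step of a 1.3-fold higher number from compound 3 to compound 4 (0.12 log units; within the scatter) is therefore expected to be small, with a slight lean toward a higher number. Compound 4 is estimated at 4500 nM, with a range of 2000 nM to 10000 nM.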

Compound 4, half-maximal inhibitory concentration: 5700 nM
Compound 4: the middle estimate sits 1.3-fold (0.10 log units) below what was measured; the range from low to high includes it.
By their numbers in this assay, from the lowest: compounds 3, 1, 2 and 4 (each within the scatter of the next).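

In this assay, within the data shown here, the only step that touches the benzyl ether, a 1.7-fold higher number from compound 3 to compound 4 (0.22 log units; within the scatter), stays within the scatter, so 3-chlorobenzyl and benzyl cannot be told apart on this aryl urea. The chloro group on this aromatic carbon is therefore not required for antiproliferative activity at this level, and the benzyl ether joins the aryl group on the urea nitrogen as a second place where a single change has produced no step beyond the scatter across these four compounds. No measurement shown here bears on how either group acts in these cells.

The chloro-to-hydrogen change is shown only on the 4-(trifluoromethyl)phenyl urea, so its size on the 3-fluorophenyl and 2-fluorophenyl ureas remains open. Also open, as far as these compounds go, is whether this aromatic carbon tolerates more than chloro or hydrogen, for example a methoxy group, an amine or a carboxylic acid, and whether a longer chain in place of the benzyl group would move the number beyond the scatter.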